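A few compounds are considered here, and "the series" means these few. Any claim that something is new, unique, unknown or untested is made for them only; others in the source may bear on it.

Of the compounds shown here, two have so far been measured in an assay on isolated protein for inhibition of polyamine deacetylase HDAC10 (Homo sapiens), read by fluorescence; a lower number here means a stronger inhibitor, a higher number a weaker inhibitor. Compound 1 `O=C(CCCCC[C@H](NC(=O)[C@@H]1CCCC(=O)N1)C(=O)Nc1ccccc1)NO` gives 51 nM there, while compound 2 `O=C(CCCCCCC(=O)Nc1cccc(C(F)(F)F)c1)NO` gives 374 nM, the higher of the two numbers, and its gap to compound 1 lies beyond the scatter. Compound 3 `Cc1cccc(NC(=O)CCCCCCC(=O)NO)c1` is not yet measured in this assay. It differs from compound 2 by methyl in place of trifluoromethyl on an aromatic carbon. Among the compounds with values here, no measured pair shows how this swap moves the half-maximal inhibitory concentration, so the change from compound 2 to compound 3 is expected to be small and of no firm direction, with a 1.1-fold lower number from compound 2 to compound 3 (0.03 log units; within the scatter) as the expected step. Compound 3 is therefore estimated at 350 nM, within a range of 120 nM to 1000 nM.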

Compound 3, half-maximal inhibitory concentration: 503 nM
For compound 3 the middle estimate is 1.4-fold (0.16 log units) below the measured one; measured number inside the range.
By their numbers in this assay, from the lowest: compound 1; then compounds 2 and 3 (each within the scatter of the next).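

In this assay, within the data shown here, methyl in place of trifluoromethyl on an aromatic carbon gives a 1.3-fold higher number from compound 2 to compound 3 (0.13 log units; within the scatter), the first reading of this swap. At this place, meta to a large group, the assay does not separate the two groups, even though three fluorine atoms leave with the change. No measurement on hand bears on this result.

Going by these compounds, whether a nitrile, an amine or a carboxylic acid on this carbon would also stay within the scatter of compound 2 remains open. So does whether the same swap behaves alike on a longer chain.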